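The source may report more compounds than this note shows. Statements on the series, on what has been measured and on what is new or still open speak of the compounds shown alone.

Measured so far: compound 1 `C[C@H](NC(=O)Nc1ccccc1F)c1ccccc1` with 98%; compound 2 `C[C@@H](NC(=O)Nc1cccc(F)c1)c1ccccc1` with 99%; compound 3 `C[C@H](NC(=O)Nc1cccc(F)c1F)c1ccccc1` with 100%.

All three were tested in an ADME assay on the whole organism with Oryza sativa as the target, tested at 0.1 uM; on this read-out higher numbers stand for a weaker effect at the one concentration tested and lower numbers for a stronger effect. Compound 1 and compound 3 differ by fluoro in place of hydrogen on an aromatic carbon. Compound 2 has the same atoms as compound 1 joined differently; the difference between the two cores is not broken down here. The values of compound 1, compound 2 and compound 3 all lie within the scatter of one another, so no order among them can be read from this assay .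

Compound 4 `C[C@@H](NC(=O)Nc1cc(F)ccc1F)c1ccccc1` is not yet measured. It differs from compound 2 by fluoro in place of hydrogen on an aromatic carbon. This is the same kind of change as that from compound 1 to compound 3, though the surroundings differ: in compound 3 the fluoro enters ortho to a fluoro group and meta to a large group, whereas in compound 4 it enters ortho to a large group and para to a fluoro group. The step is expected to be a number 0.5 percentage points higher from compound 2 to compound 4 (within the scatter), because the earlier instance gave a number 2 percentage points higher from compound 1 to compound 3 (within the scatter). Compound 4 is therefore estimated at 99.5%, with a range from 95% to 100%.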

Compound 4, a percentage reported as activity, at one concentration (the size of the read-out at that concentration, not a potency): 100%
Estimate against measurement, compound 4: 0.5 percentage points below; the range from low to high includes it.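

In this assay, fluoro in place of hydrogen on an aromatic carbon gives a number 1 percentage points higher from compound 2 to compound 4 (within the scatter), and the two instances of this change agree: the same change on two cores in this assay, a number 2 percentage points higher (within the scatter) from compound 1 to compound 3 and a number 1 percentage points higher (within the scatter) from compound 2 to compound 4, 1 percentage points apart, within the scatter of two such steps. So far as these two cores go, the change carries over in the limited sense that neither step can be told apart from the scatter of repeated measurements. This does not show that fluoro at either place acts on this read-out at all, and agreement between two steps this small says nothing about how a step of real size would carry from one core to another.

All four compounds carry only fluoro on the ring attached to the urea nitrogen, and the other phenyl ring has no substituent. The compounds shown therefore leave open whether a chloro, methoxy, trifluoromethyl or amine group on either ring would give a number that stands clear of the scatter.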